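Pyridone-lactam series: aryl substituent swaps at the dichloro ring

A few compounds are considered here, and "the series" means these few. Any claim that something is new, unique, unknown or untested is made for them only; others in the source may bear on it.

Measured so far:
Compound 1, `COC(c1cc(Cl)c2c(c1Cl)C(=O)N(Cc1c(C)cc(C)[nH]c1=O)CC2)C1CCOCC1`, 1460 nM; 9 nM (2 entries)
Compound 2, `Cc1cc(C)c(CN2CCc3c(Cl)cc([C@@H](CO)[C@@H]4CCOC4)c(Cl)c3C2=O)c(=O)[nH]1`, 2910 nM
Compound 3, `Cc1cc(C)c(CN2CCc3c(Cl)cc([C@@H](C)CO)c(Cl)c3C2=O)c(=O)[nH]1`, 1040 nM

In an assay on cells for inhibition of histone-lysine N-methyltransferase EZH2 (Homo sapiens), read by ELISA, with a stated time of 72 h (a lower number here means a stronger inhibitor, a higher number a weaker inhibitor), compound 1 shows two widely separated entries, (the several entries of compound 1 in this assay, 1460 nM; 9 nM (2 entries)), so it gives no single number to anchor the series. Among the compounds with one number, compound 3 stands lowest; its nearest neighbour is compound 2, and the step from compound 2 to compound 3 is a 2.8-fold lower number from compound 2 to compound 3 (0.45 log units; beyond the scatter), the only measured step on the side group at this aromatic carbon.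

Compound 4, `Cc1cc(C)c(CN2CCc3c(Cl)cc(-c4c(C)noc4C)c(Cl)c3C2=O)c(=O)[nH]1`, is not yet measured. Its change from compound 3 is 3,5-dimethyl-1,2-oxazol-4-yl in place of 1-(hydroxymethyl)ethyl on an aromatic carbon. The measured step bears only loosely: it trades one saturated side group for another, whereas compound 4 brings in an aromatic ring. Since that step was modest, no large movement beyond the scatter is expected either way, with a slight lean towards a lower number for compound 4, so that in this assay compound 4 is estimated at 500 nM, range 80 nM to 3000 nM.
The estimated step from compound 3 to compound 4 is a 2.1-fold lower number from compound 3 to compound 4 (0.32 log units; beyond the scatter).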

Compound 4, half-maximal inhibitory concentration in the histone-lysine N-methyltransferase EZH2 assay: 17 nM
Estimate against measurement, compound 4: 29-fold (1.47 log units) above, outside the stated range (below it).
By their numbers in the histone-lysine N-methyltransferase EZH2 assay, from the lowest: compound 4; then compound 3; then compound 2.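

In the histone-lysine N-methyltransferase EZH2 assay, 3,5-dimethyl-1,2-oxazol-4-yl in place of the saturated side groups gives a 61-fold lower number from compound 3 to compound 4 (1.79 log units; beyond the scatter) and a 170-fold lower number from compound 2 to compound 4 (2.23 log units; beyond the scatter), both far larger than the earlier 2.8-fold lower number from compound 2 to compound 3 (0.45 log units; beyond the scatter). The side group on this aromatic carbon can therefore move the number much further than the saturated pair showed, and compound 4 reaches its low number with no hydrogen-bond donor and no defined stereocentre in that group. In a physicochemical assay for lipophilicity, at pH 7.4 (a lower number here means a more polar compound, a higher number a more lipophilic compound), compound 3 gives 2.5 and compound 4 gives 3.1. The same change also moves the compound in the physicochemical assay: the measured distribution coefficient of compound 3, 2.5, and of compound 4, 3.1, a number 0.60 log units higher (beyond the scatter)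

Whether the drop in the histone-lysine N-methyltransferase EZH2 assay follows the aromatic ring, its two methyl groups or the higher distribution coefficient remains open, with a single aromatic group shown. Also open, on these data alone, is whether a plain phenyl or pyridine ring on this carbon would give a similar number.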